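Phenyl halogen pattern: expected value for compound 3

A few compounds are considered here, and "the series" means these few. Any claim that something is new, unique, unknown or untested is made for them only; others in the source may bear on it.

Among the compounds with values here, in a functional assay on HCT-116 cells (Homo sapiens) for antiproliferative activity, read by MTT assay, with a stated time of 72 h (on this read-out higher numbers stand for weaker inhibition and lower numbers for stronger inhibition), compound 1 `NC1=NC2(CCOCC2)N(OCCCOc2cccc(Cl)c2Cl)C(N)=N1` gives 5 nM and compound 2 `NC1=NC2(CCOCC2)N(OCCCOc2cc(Cl)c(Cl)cc2Cl)C(N)=N1` gives 2750 nM, the higher of the two numbers so far. Compound 3 `NC1=NC2(CCOCC2)N(OCCCOc2cccc(Br)c2)C(N)=N1` alters the same group of compound 2: 3-bromophenyl in place of 2,4,5-trichlorophenyl on an oxygen on a saturated carbon, with 3-bromophenyl in place of 2,4,5-trichlorophenyl on an oxygen on a saturated carbon. Within the data shown here, only one measured step bears on this. It is a 550-fold higher number from compound 1 to compound 2 (2.74 log units; beyond the scatter), large and beyond the scatter, and it arises at this same place. Compound 3 gives up the 2,4,5-trichlorophenyl group that compound 2 carries, so a return toward lower numbers in this assay is expected. Among the measured compounds shown here, no measured compound carries 3-bromophenyl, so a full return is not assumed. The expected change is a 28-fold lower number from compound 2 to compound 3 (1.44 log units; beyond the scatter), a large fall. Compound 3 is estimated at 100 nM, with an expected range of 12 nM to 900 nM.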

Compound 3, half-maximal inhibitory concentration: 40 nM
Compound 3: middle estimate off by 2.5-fold (0.40 log units), on the high side; the range from low to high includes it.
By their numbers in this assay, from the lowest: compound 1; then compound 3; then compound 2.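

In this assay the change to 3-bromophenyl gives a 69-fold lower number from compound 2 to compound 3 (1.84 log units; beyond the scatter) and shows that the high number of compound 2 does not extend to every other halogen pattern on this phenyl group. A single bromine keeps much of the strength in this series, but the change from 2,3-dichlorophenyl still gives an 8.0-fold higher number from compound 1 to compound 3 (0.90 log units; beyond the scatter) and so leaves compound 1 with the lowest number of the three. No supporting data accompany these values to explain the order of the three groups.

From the compounds shown here alone, it remains open whether 3-chlorophenyl would read like 3-bromophenyl, which would separate the identity of the halogen from the pattern on the ring. Also open, going by these compounds, is how a phenyl group carrying an amine or a carboxylic acid in place of the halogens would read at this position.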